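Adding a chlorine to the benzyl group of compound 2

The source may report more compounds than this note shows. Statements on the series, on what has been measured and on what is new or still open speak of the compounds shown alone.

Compound 1 `CC1=C(C(=O)Nc2ccc(Br)cc2)C(c2ccc(Cl)cc2Cl)N=C(SCc2ccccc2Cl)N1` gives 28.7% in a functional assay on the whole organism (artery, strain albino) with Rattus norvegicus as the target, with a stated time of 240 min, at a dose of 10 mg/kg by the oral route; on this read-out higher numbers stand for more inhibition at the one dose given (going by the name of the read-out) and lower numbers for less inhibition
Compound 2 `COc1ccc(C2N=C(SCc3ccccc3)NC(C)=C2C(=O)Nc2ccc(Br)cc2)cc1` gives 13.3% in this assay

Of the two compounds measured, compound 2 stands lowest, and the gap to compound 1 lies beyond the scatter. Compound 3 `COc1ccc(C2N=C(SCc3ccccc3Cl)NC(C)=C2C(=O)Nc2ccc(Br)cc2)cc1` is not yet measured. It differs from compound 2 by one change, (chloro in place of hydrogen on an aromatic carbon). Among the compounds with values here, no measured pair shows this change alone, so no step can be read off for it. A small rise is expected in this assay, with a step from compound 2 to compound 3 of a number 6.7 percentage points higher from compound 2 to compound 3 (within the scatter). For compound 3 the expected value is 20%, in a range from 5% to 36%.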

Compound 3, a percentage reported as inhibition, in the whole organism at one dose (the size of the read-out at that dose, not a potency): 15.4%
Estimate against measurement, compound 3: 4.6 percentage points above, and the stated range covers the measured number.
By their numbers in this assay, from the lowest: compounds 2 and 3 (each within the scatter of the next); then compound 1.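

In this assay, putting 2-chlorobenzyl in place of benzyl gives a number 2.1 percentage points higher from compound 2 to compound 3 (within the scatter) and so leaves the read-out at this position unchanged at the one dose given. With the 2-chlorobenzyl group held in common, 4-methoxyphenyl in place of 2,4-dichlorophenyl on the saturated ring carbon gives a number 13.3 percentage points lower from compound 1 to compound 3 (beyond the scatter) and so marks that ring carbon as the place where the read-out moves. Nothing at hand explains either step. Going by these compounds, it remains open how an amine or a carboxylic acid on the benzyl ring would read, or a longer chain in place of benzyl.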